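Swapping the sulfonyl aryl group: stability of compound 3

This account rests on a few compounds, and the source may have more. Where it says the series, first, only, none or still open, it means among the compounds named here.

Measured compounds:
compound 1 `Cc1cn(Cc2ccc(Cl)cc2Cl)c2c(-c3nnc(NS(=O)(=O)c4cc(Cl)c(Cl)s4)o3)cc(F)cc12`, 62.7%
compound 2 `Cc1cn(Cc2ccc(Cl)cc2Cl)c2c(-c3cc(NS(=O)(=O)c4cc(Cl)c(Cl)s4)no3)cc(F)cc12`, 46.8%

Going by the values given here, in an ADME assay on microsomes from liver (Homo sapiens) for metabolic stability, with a stated time of 30 min (on this read-out higher numbers stand for a more stable compound and lower numbers for a less stable compound), compound 1 gives 62.7%, the higher of the two numbers measured so far; compound 2 gives 46.8%, lower by a difference that lies beyond the usual scatter. Compound 3 `Cc1cn(Cc2ccc(Cl)cc2Cl)c2c(-c3nnc(NS(=O)(=O)c4ccc(Cl)c(Cl)c4)o3)cc(F)cc12` carries the same core and differs from compound 1 only by 3,4-dichlorophenyl in place of 4,5-dichlorothiophen-2-yl on a sulfonyl sulfur. Among the compounds with values here, no measured pair shows this change, so there is no precedent to lean on. The step from compound 1 to compound 3 in this assay is expected to be a number 2.7 percentage points lower from compound 1 to compound 3 (within the scatter), that is none beyond the scatter. Compound 3 is therefore estimated at 60%, with a range from 40% to 80%.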

Compound 3, percent of the compound remaining: 72.1%
For compound 3 the middle estimate is 12.1 percentage points below the measured one; low and high end bracket the measured number.
By their numbers in this assay, from the lowest: compound 2; then compounds 1 and 3 (each within the scatter of the next).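

In this assay, 3,4-dichlorophenyl on the sulfonyl sulfur in place of 4,5-dichlorothiophen-2-yl gives a number 9.4 percentage points higher from compound 1 to compound 3 (within the scatter). At this position, then, the five-membered ring with its sulfur can give way to a six-membered ring of carbon only with no change that stands clear of the scatter. Nothing at hand accounts for the size of this step. Still open, on these data alone, is how an unsubstituted phenyl, a pyridine or a short alkyl chain on the sulfonyl sulfur would fare in this assay, and whether the same swap would give a similar step on the core of compound 2.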